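This account rests on a few compounds, and the source may have more. Where it says the series, first, only, none or still open, it means among the compounds named here.

Among the measured compounds shown here, compound 2 `CC(O)(CSc1ccccc1)c1nc(-c2ccc(F)c(Cl)c2)no1` gives 5500 nM in a functional assay on DU-145 cells (Homo sapiens) for cytotoxicity, read by MTT assay (a lower number here means a stronger inhibitor, a higher number a weaker inhibitor), the second highest of the three numbers measured so far. Compound 1 `CC(O)(CSc1ccc(F)cc1)c1nc(-c2ccc(Cl)cc2)no1` gives 36300 nM in this assay, a higher number than compound 2 and beyond the scatter. For the measured compounds named here, compound 3 `CC(O)(CSc1ccc(Cl)cc1)c1nc(-c2ccc(F)c(Cl)c2)no1` gives 500 nM in this assay, and the only measured single-place step, an 11-fold lower number from compound 2 to compound 3 (1.04 log units; beyond the scatter), lies at a different place in the molecule from the change considered here. Compound 4 `CC(O)(CSc1ccccc1)c1nc(-c2ccc(Cl)cc2)no1` differs from compound 2 by 4-chlorophenyl in place of 3-chloro-4-fluorophenyl on an aromatic carbon. Going by the values given here, no measured step covers this change directly. Compound 1 carries the same 4-chlorophenyl group as compound 4 and compound 3 the same 3-chloro-4-fluorophenyl group as compound 2, but each also differs from compound 4 in a second place, so their numbers give only a weak hint that the 4-chlorophenyl pairing goes with a higher number. The step is therefore expected to be a 2.2-fold higher number from compound 2 to compound 4 (0.34 log units; beyond the scatter), upward, with the scatter not ruled out. Compound 4 is estimated at 12000 nM, in the range 3000 nM to 50000 nM.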

Compound 4, half-maximal inhibitory concentration: 4500 nM
Compound 4: the middle estimate sits 2.7-fold (0.43 log units) above what was measured, and the stated range covers the measured number.
By their numbers in this assay, from the lowest: compound 3; then compounds 4 and 2 (each within the scatter of the next); then compound 1.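

In this assay, 4-chlorophenyl in place of 3-chloro-4-fluorophenyl on the aromatic carbon between two ring nitrogen atoms gives a 1.2-fold lower number from compound 2 to compound 4 (0.09 log units; within the scatter), so this change does not separate the two groups when the rest of compound 2 is held fixed. The larger effect sits on the other aromatic ring: hydrogen in place of fluoro gives an 8.1-fold lower number from compound 1 to compound 4 (0.91 log units; beyond the scatter), a step at the same kind of site as the chloro change already seen, but with 4-chlorophenyl as the partner group. Nothing measured bears on the reason for either result.

The compounds shown leave open whether chloro in place of hydrogen on that other ring has the same size with 4-chlorophenyl as with 3-chloro-4-fluorophenyl. They also leave open how a methoxy group or an amine on either ring would read here.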